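The source may hold more compounds than are shown below. What is called first, only, known or untested is meant among the compounds shown, and "the series" means these compounds.

Measured compounds:
Compound 1, `CCc1ccc(-c2noc(Cc3c[nH]c4ccccc34)n2)cc1`, in a functional assay on cells (Splenocyte, Mus musculus, strain BALB/c) for inhibition, read by scintillation counting and thymidine incorporation, with stated times of 48 h and 8 h (a lower number here means a stronger inhibitor, a higher number a weaker inhibitor), compound 1 gives 7500 nM.
Compound 2, `COc1cc(-c2nc(Cc3c[nH]c4ccccc34)no2)cc(OC)c1OC`, in this assay compound 2 gives 11000 nM.
Compound 3, `COc1ccc(-c2nc(Cc3c[nH]c4ccccc34)no2)c(OC)c1`, in this assay compound 3 gives 8600 nM.

All three compounds share the same core and differ only in the substituents on the six-membered aromatic ring of carbon only. Compound 2 carries three methoxy groups there and gives the numerically largest value of the three, but its gap to compound 3 and its gap to compound 1 both lie within the usual scatter of repeated measurements, so none of the three can be called the stronger or the weaker inhibitor on these numbers alone.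

Compound 4, `COc1cc(OC)cc(-c2nc(Cc3c[nH]c4ccccc34)no2)c1`, has not yet been measured. It is derived from compound 2 by a single change: hydrogen in place of methoxy on an aromatic carbon. For the measured compounds named here, no pair of measured compounds shows what this particular change does, so the expectation rests on the narrow spread of the three measured values. Since compounds 1, 2 and 3 with quite different substitution on that ring all fall within the scatter of one another, the step of a 1.2-fold lower number from compound 2 to compound 4 (0.06 log units; within the scatter) is expected to be small, with no direction beyond the scatter. Compound 4 is therefore estimated at 9500 nM, with a range from 4500 nM to 20000 nM.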

Compound 4, half-maximal inhibitory concentration: > 50000 nM
Compound 4 was reported as a limit; the forecaster's own chance of this, stated with the estimate: 15%; middle value at least 5.2-fold (0.72 log units) from the limit.
By their numbers in this assay, from the lowest: compounds 1, 3 and 2 (each within the scatter of the next). At a limit, above all of these: compound 4.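

Compound 4 gives > 50000 nM in this assay, which is a limit of the assay and not a number: the limit of > 50000 nM in this assay, at which 1 of the 4 values shown sits. Hydrogen in place of methoxy on this aromatic carbon, ortho to two methoxy groups and para to a large group, brings an at least 4.5-fold higher number from compound 2 to compound 4 (0.65 log units; beyond the scatter), so compound 4 is the weaker inhibitor of this pair, and the true size of the step cannot be read beyond what the limit allows. The earlier compounds shown here held no pair differing in one place and so could say nothing about any single position, whereas this pair shows that the methoxy group at this position matters in this assay, although the data do not tell through which property.

Whether this result depends on methoxy itself or on having any group at this position stays open, since the compounds shown do not tell what a hydroxyl group, a fluorine atom or an amine would do there. Nor do they show whether a longer chain such as ethoxy would keep the value of compound 2, or what the same change does at the two other methoxy positions of compound 2.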